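Linker swap at the aryl terminus of an isothiocyanate series

This account rests on a few compounds, and the source may have more. Where it says the series, first, only, none or still open, it means among the compounds named here.

Working notes on a small set sharing one core. Compound 1 `CN(C)C(=O)c1cc2cnc(Nc3ccc(S(=O)(=O)NCCCN=C=S)cc3)nc2n1C1CCCC1` is the reference. Among the compounds with values here, in a functional assay on A549 cells (Homo sapiens) for inhibition, read by CCK-8 assay, with a stated time of 72 h, tested at 1 uM (a higher number here means a stronger effect of the compound at the concentration tested, a lower number a weaker effect), compound 1 gives 58.9%, the highest of the three numbers so far. Compound 3 `CN(C)C(=O)c1cc2cnc(Nc3ccc(C(=O)NCCCCCN=C=S)cc3O)nc2n1C1CCCC1` is the nearest to it; in this assay compound 3 gives 23.1%, a gap beyond the scatter. Compound 2 `CN(C)C(=O)c1cc2cnc(Nc3ccc(C(=O)NCCCCCCN=C=S)cc3F)nc2n1C1CCCC1` is the furthest; in this assay compound 2 gives -11.8%, also a gap beyond the scatter. Within the data shown here, compounds 2 and 3 differ from compound 1 in more than one place, so no single step between measured compounds can be read off.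

Compound 4 `CN(C)C(=O)c1cc2cnc(Nc3ccc(NC(=O)CCCCN=C=S)cc3)nc2n1C1CCCC1` is the next entry. It differs from compound 1 as follows: a group of 10 heavy atoms (6 carbon, 2 nitrogen, 1 oxygen, 1 sulfur; no ring) in place of a group of 10 heavy atoms (4 carbon, 2 nitrogen, 2 oxygen, 2 sulfur; no ring), on an aromatic carbon The sulfonamide tether carrying the isothiocyanate is thus replaced by a reversed amide tether, para to a large group on the ring.

With no single-point comparison available, the expectation rests on the three numbers only: the two carbonyl-linked compounds sit well below compound 1, which points to a downward step, though their ring substituents confound this. The step from compound 1 to compound 4 is expected to be a number 26.9 percentage points lower from compound 1 to compound 4 (beyond the scatter), a loss beyond the scatter. For compound 4 the estimated value in this assay is 32%, with a range from 5% to 58%.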

Compound 4, a percentage reported as inhibition, at one concentration (the size of the read-out at that concentration, not a potency): 38.2%
The estimate for compound 4 lay 6.2 percentage points below the measured number, within the range that was stated.
By their numbers in this assay, from the lowest: compound 2; then compound 3; then compound 4; then compound 1.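

Within the data shown here, this is the first step that can be read at a single place, on an aromatic carbon para to a large group, with the rest of compound 1 unchanged. In this assay, replacing the sulfonamide tether with the reversed amide tether, with 10 heavy atoms in both groups, 1 hydrogen-bond donor in each and no ring in either, gives a number 20.7 percentage points lower from compound 1 to compound 4 (beyond the scatter), so the make-up of the tether matters at this position even when its heavy-atom count is unchanged, while compound 4 still gives 38.2%. No measurement available here explains the loss.

The step changes the linking group, its direction and the carbon chain together, so it cannot be assigned to any one of them, and steps involving compounds 2 and 3 cannot be read. Still open, from the compounds shown here alone, are how a sulfonamide tether with a longer chain, an amide tether in the opposite direction on the same unsubstituted ring, or a terminal amine or carboxylic acid in place of the isothiocyanate would compare with compound 1.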